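A few compounds are considered here, and "the series" means these few. Any claim that something is new, unique, unknown or untested is made for them only; others in the source may bear on it.

Measured so far:
compound 1, `C(=C/c1ncnc2c1ncn2C1CCOCC1)\c1ccccc1`, 66%
compound 2, `C(=C/c1ncnc2c1ncn2C1CCOCC1)\c1ccco1`, 35%

Compound 2 stands lowest of the two values in a functional assay on K562 cells (Homo sapiens) for inhibition, read by thymidine incorporation, with a stated time of 48 h, tested at 10 ug/mL; on this read-out higher numbers stand for more inhibition at the one concentration tested (going by the name of the read-out) and lower numbers for less inhibition; its nearest neighbour is compound 1, separated by the step of a number 31 percentage points lower from compound 1 to compound 2 (beyond the scatter). Compound 3, `C(=C/c1ncnc2c1ncn2C1CCOCC1)\c1cccs1`, is not yet measured. It differs from compound 2 by thiophen-2-yl in place of furan-2-yl on a double-bonded chain carbon bound to a double-bonded chain carbon. Among the measured compounds shown here, only one measured step bears on this change: a number 31 percentage points lower from compound 1 to compound 2 (beyond the scatter), which shows that swapping the group on a double-bonded chain carbon bound to a double-bonded chain carbon moved the number by a large amount. For the measured compounds named here, no measured pair sets furan-2-yl against thiophen-2-yl, so the direction rests on weaker footing: compound 2, with 35%, is the lower of the two values seen, and compound 1 the higher. A moderate rise is expected, and the expected step is a number 15 percentage points higher from compound 2 to compound 3 (beyond the scatter), within a broad range. Compound 3 is estimated at 50%, between 25% and 75%.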

Compound 3, a percentage reported as inhibition, at one concentration (the size of the read-out at that concentration, not a potency): 65%
Estimate against measurement, compound 3: 15 percentage points below, within the range that was stated.
By their numbers in this assay, from the lowest: compound 2; then compounds 3 and 1 (each within the scatter of the next).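

In this assay, exchanging furan-2-yl for thiophen-2-yl on a double-bonded chain carbon bound to a double-bonded chain carbon gives a step beyond the scatter (a number 30 percentage points higher from compound 2 to compound 3 (beyond the scatter)), so two five-membered aromatic rings with 1 hetero atom and 5 heavy atoms each are not interchangeable at this position. Thiophen-2-yl and phenyl, by contrast, lie within the scatter of each other (a number 1 percentage points lower from compound 1 to compound 3 (within the scatter)), which leaves furan-2-yl as the one group of the three that stands apart. Nothing available accounts for the separation of the oxygen and sulfur rings.

On these data alone, it remains open whether a group without an aromatic ring, such as an amine or a longer alkyl chain, would keep the number at the level of thiophen-2-yl and phenyl. The single tested concentration also leaves the relative potencies of these compounds open.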